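A few compounds are considered here, and "the series" means these few. Any claim that something is new, unique, unknown or untested is made for them only; others in the source may bear on it.

Measured compounds in a functional assay on the whole organism with Rattus norvegicus as the target, at a dose of 20 mg/kg by the oral route; a lower number here means less inhibition, a higher number more inhibition at the dose given (going by the name of the read-out):
Compound 1, `NC(=O)/C=C1\CCc2c(F)cccc21`, gives 40%.
Compound 2, `CC(C)NC(=O)/C=C1\CCc2ccc(F)cc21`, gives 45%.
Compound 3, `O=C(/C=C1\CCc2cc(F)c(F)cc21)NC1CC1`, gives 30%.

Compound 2 carries the highest number of the three, but its nearest neighbour, compound 1, sits within the usual scatter of it, so the two cannot be ordered. Only compound 3 lies clearly apart, with a number beyond the scatter below that of compound 2. Within the data shown here, compounds 1 and 3 differ from compound 2 in more than one place, so no single step between measured compounds is available.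

Compound 4, `O=C(/C=C1\CCc2ccc(F)cc21)N1CCC1`, has not yet been measured in this assay. It differs from compound 2 as follows: azetidin-1-yl in place of isopropylamino on a carbonyl carbon. The amide hydrogen of compound 2 is thus lost and the nitrogen becomes part of a four-membered ring.

Among the measured compounds shown here, no measured pair shows what such an exchange on the carbonyl carbon does, so the expectation rests on compound 2 alone and is kept near it. The estimated step from compound 2 to compound 4 is a number 5 percentage points lower from compound 2 to compound 4 (within the scatter), which is expected to fall within the scatter. Compound 4 is therefore expected to give about 40% in this assay, with a plausible range from 20% to 60%.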

Compound 4, a percentage reported as inhibition, in the whole organism at one dose (the size of the read-out at that dose, not a potency): 14%
Compound 4: the middle estimate sits 26 percentage points above what was measured, outside the stated range (below it).
By their numbers in this assay, from the lowest: compound 4; then compounds 3, 1 and 2 (each within the scatter of the next, the first and the last beyond it).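

Among these compounds, the first single-place step, read in this assay, is a number 31 percentage points lower from compound 2 to compound 4 (beyond the scatter), with azetidin-1-yl in place of isopropylamino on a carbonyl carbon. This position is therefore not indifferent to the group it carries, even though the two groups have the same counts of heavy atoms, carbon and nitrogen; they differ in that azetidin-1-yl has a four-membered non-aromatic ring and no hydrogen-bond donor, whereas isopropylamino has no ring and a hydrogen-bond donor. Nothing available explains the size of this step.

Among the compounds shown here, the single step changes the ring and the amide hydrogen together, so it cannot assign the loss to either one; on the core of compound 2, dimethylamino would remove the amide hydrogen without adding a ring, and cyclobutylamino would add a ring while keeping that hydrogen. From the compounds shown here alone, whether the loss extends to other ring amides on this carbonyl carbon also remains open, and pyrrolidin-1-yl or piperidin-1-yl on the same core would test this.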